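The source may hold more compounds than are shown below. What is called first, only, known or untested is meant among the compounds shown, and "the series" means these compounds.

These notes follow the series in a functional assay on MDA-MB-436 cells (Homo sapiens) for antiproliferative activity, read by MTT assay, with a stated time of 24 h; on this read-out higher numbers stand for weaker inhibition and lower numbers for stronger inhibition. In this assay compound 1 `O=C(O)CC(NC(=O)c1cccc(Br)c1)c1ccccc1` returns only a limit, > 100000 nM, and no number. Compound 2 `O=C(O)CC(NS(=O)(=O)c1ccccc1)c1ccccc1` also returns only a limit, > 100000 nM. Together these two compounds sit at the limit of > 100000 nM in this assay, at which 2 of the 3 values shown sit, which leaves compound 1 with no measured position of its own. Within the data shown here, compound 3 `O=C(O)CC(NS(=O)(=O)c1cc(F)cc(F)c1)c1ccccc1` is the only member with a number so far, 69400 nM.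

Compound 4 `O=C(O)CC(NC(=O)c1cccc(Br)c1)c1ccccc1F` is the core of compound 1 with fluoro in place of hydrogen on an aromatic carbon, ortho to a large group (fluoro in place of hydrogen on an aromatic carbon). Among the measured compounds shown here, no measured pair tests this change. The expected step of an at least 1.1-fold lower number from compound 1 to compound 4 (0.04 log units; that floor lies within the scatter) is none beyond the scatter, and any movement is expected to be towards stronger inhibition. Even compound 3 reaches only 69400 nM, so a further reading without a number is the likeliest expected outcome for compound 4. Should a number appear, compound 4 is estimated at 90000 nM. The estimated range for compound 4 runs from 45000 nM to 180000 nM.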

Compound 4, half-maximal inhibitory concentration: > 100000 nM
Compound 4 was reported as a limit (the forecaster's own chance of this, stated with the estimate: 70%); middle value at least 1.1-fold (0.04 log units) from the limit.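

The step from compound 1 to compound 4 cannot be read in this assay, because both readings are limits and not numbers: the limit of > 100000 nM in this assay, at which 3 of the 4 values shown sit.

The compounds shown leave open what fluoro in place of hydrogen on an aromatic carbon does to inhibition on the core of compound 1.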